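This account rests on a few compounds, and the source may have more. Where it says the series, first, only, none or still open, it means among the compounds named here.

Measured in a functional assay on MCF7 cells (Homo sapiens) for antiproliferative activity, read by MTT assay, with a stated time of 48 h; on this read-out lower numbers stand for stronger inhibition and higher numbers for weaker inhibition:
- compound 1 `CCCCCCCCn1cc(COC[C@@H]2OC[C@H](N)[C@@H]2O)nn1`: 28100 nM
- compound 2 `CCCCCCCCCn1cc(COC[C@@H]2OC[C@H](N)[C@@H]2O)nn1`: 12400 nM
- compound 3 `CCCCCCCCCCCCCCCCn1cc(COC[C@@H]2OC[C@H](N)[C@@H]2O)nn1`: 3300 nM

Compound 2 stands in the middle of the three, with a 2.3-fold lower number from compound 1 to compound 2 (0.36 log units; beyond the scatter) on one side and a 3.8-fold lower number from compound 2 to compound 3 (0.57 log units; beyond the scatter) on the other. The open question is compound 4 `CCCCCCCCCn1cc(COC[C@@H]2OC[C@H](N)[C@H]2O)nn1`, and its relation to the middle compound is the two compounds have the same atoms and bonds and differ only in configuration as drawn: 1 of 3 stereo elements differ; a stereocentre at a saturated ring carbon is drawn S in compound 2 and R in compound 4.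

Going by the values given here, none of the measured steps changes a stereocentre. All of them are changes on the saturated chain, including the widest, an 8.5-fold lower number from compound 1 to compound 3 (0.93 log units; beyond the scatter). They are modest, but they set only the scale of movement in this small series and say nothing on configuration. No direction can therefore be derived for this assay, and no step beyond the scatter is expected, although the data cannot exclude one. The expected change is a 1.0-fold higher number from compound 2 to compound 4 (0.02 log units; within the scatter), with a wide range on both sides.

Compound 4 is estimated at 13000 nM, with an expected range of 5000 nM to 35000 nM.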

Compound 4, half-maximal inhibitory concentration: > 128000 nM
Compound 4 gave a limit, no number (the forecaster's own chance of this, stated with the estimate: 7%); middle value at least 9.8-fold (0.99 log units) from the limit.
By their numbers in this assay, from the lowest: compound 3; then compound 2; then compound 1. At a limit, above all of these: compound 4.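

Compound 4 gives > 128000 nM in this assay, which is a limit of the assay and not a number. The configuration at this saturated ring carbon, drawn S in compound 2 and R in compound 4, carries an at least 10-fold higher number from compound 2 to compound 4 (1.01 log units; beyond the scatter), a large step, whereas the chain changes stayed modest, the widest being an 8.5-fold lower number from compound 1 to compound 3 (0.93 log units; beyond the scatter). The step can be assigned to this one stereocentre because nothing else separates the pair: the fact that compounds 2 and 4 differ only in the configuration as drawn

Still open, on these data alone, is whether the same inversion has a comparable effect on the chains of compound 1 and compound 3, and what inverting either of the other two stereocentres does. Also open, as far as these compounds go, is how a carboxylic acid or an acetamide in place of the amine would read with the configuration of compound 2.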